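From methoxy to bromo on the aromatic ring

The compounds below may be only part of what the source reports. "The series", "measured", "known", "first", "only" and "open" are said of these compounds alone.

Values in a functional assay on NRK-49F cells (Rattus norvegicus) for cytotoxicity, read by MTT assay, with a stated time of 24 h (a lower number here means a stronger inhibitor, a higher number a weaker inhibitor), stand as follows:
compound 1 `C/C(=N\NC(=O)/C(C#N)=C/c1ccc(O)cc1)c1c(O)c2ccc(O)cc2oc1=O` gives 61300 nM
compound 2 `COc1cc(/C=C(\C#N)C(=O)N/N=C(\C)c2c(O)c3ccc(O)cc3oc2=O)ccc1O` gives 55400 nM
compound 3 `COc1ccc(/C=C(\C#N)C(=O)N/N=C(\C)c2c(O)c3ccc(O)cc3oc2=O)cc1` gives 96100 nM

Compound 3 does not stand apart from the other two. It is reached by a 1.6-fold higher number from compound 1 to compound 3 (0.20 log units; within the scatter) and by a 1.7-fold higher number from compound 2 to compound 3 (0.24 log units; within the scatter) and both steps lie within the scatter, so no order among the three can be read.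

The next compound is compound 4 `C/C(=N\NC(=O)/C(C#N)=C/c1ccc(Br)cc1)c1c(O)c2ccc(O)cc2oc1=O` which keeps the shared core and replaces a single group, with bromo in place of methoxy on an aromatic carbon, para to a large group (bromo in place of methoxy on an aromatic carbon). Going by the values given here, no measured compound carries bromo, so the data do not show this exchange directly. The nearest evidence is the set of measured changes to groups on this aromatic ring. These are a 1.1-fold lower number from compound 1 to compound 2 (0.04 log units; within the scatter) and the two steps reaching compound 3, and the largest of them, a 1.7-fold higher number from compound 2 to compound 3 (0.24 log units; within the scatter) remains within the scatter. Going by these compounds, these steps give no ground for expecting a large move in this assay in either direction, although bromo itself remains untested.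

The estimated step is a 1.4-fold lower number from compound 3 to compound 4 (0.14 log units; within the scatter) and no change beyond the scatter is expected. For compound 4 the expected value is 70000 nM with an estimated range from 30000 nM to 150000 nM as the likely span.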

Compound 4, half-maximal inhibitory concentration: 49600 nM
Compound 4: the middle estimate sits 1.4-fold (0.15 log units) above what was measured; low and high end bracket the measured number.
By their numbers in this assay, from the lowest: compounds 4, 2, 1 and 3 (each within the scatter of the next).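

In this assay the aromatic carbon para to a large group now carries a halogen, and bromo in place of methoxy gives a 1.9-fold lower number from compound 3 to compound 4 (0.29 log units; within the scatter) in what is the largest single step among these compounds, yet it stays within the scatter. Bromo in place of hydroxy gives a 1.2-fold lower number from compound 1 to compound 4 (0.09 log units; within the scatter) and the wider exchange of 4-hydroxy-3-methoxyphenyl for 4-bromophenyl gives a 1.1-fold lower number from compound 2 to compound 4 (0.05 log units; within the scatter) so that, across all three comparisons, swapping the oxygen-bearing groups on this ring for bromo moves no number beyond the scatter, and the four compounds cannot be put in any order. Nothing measured alongside these numbers bears on why the steps stay this small.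

The compounds shown leave open whether any group at this position can shift the number beyond the scatter, since only hydroxy, methoxy and bromo appear there, and an amine, a carboxylic acid or a longer alkyl chain might behave differently. They also leave open whether chloro or fluoro would match bromo, and whether changes elsewhere on the shared core would matter more than changes on this ring.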